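The source may report more compounds than this note shows. Statements on the series, on what has been measured and on what is new or still open speak of the compounds shown alone.

Compound 1 `Nc1nc(NCCNc2ncc(-c3ncc[nH]3)c(-c3ccc(Cl)cc3)n2)ccc1[N+](=O)[O-]` carries a 4-chlorophenyl group on the shared core. In an ADME assay on microsomes from liver (Rattus norvegicus) for metabolic stability (on this read-out lower numbers stand for a shorter-lived compound and higher numbers for a longer-lived compound), compound 1 gives > 0.5 h as a limit and not as a number. Compound 2 `Nc1nc(NCCNc2ncc(-c3ncc[nH]3)c(-c3ccc(C(F)(F)F)cc3)n2)ccc1[N+](=O)[O-]` has trifluoromethyl in place of that chloro, and compound 2 reads > 0.5 h as a limit too. As far as these compounds go, compound 3 `Nc1nc(NCCNc2ncc(-c3ncc[nH]3)c(-c3cc(F)ccc3Cl)n2)ccc1[N+](=O)[O-]` carries 2-chloro-5-fluorophenyl instead, and compound 3 stands at > 0.5 h as a limit as well, so its true half-life is unknown. Together these results make up the limit of > 0.5 h in this assay, at which 3 of the 3 values shown sit, in the evidence so far.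

Compound 4 `Nc1nc(NCCNc2ncc(-c3ncc[nH]3)c(-c3ccc(F)cc3Br)n2)ccc1[N+](=O)[O-]` replaces that group with 2-bromo-4-fluorophenyl on the same aromatic carbon, and 2-bromo-4-fluorophenyl in place of 2-chloro-5-fluorophenyl on an aromatic carbon is the whole change. Going by the values given here, three measured steps bear on a swap like this one: a step that the two limits leave unreadable from compound 1 to compound 3 and a step that the two limits leave unreadable from compound 2 to compound 3 and also a step that the two limits leave unreadable from compound 1 to compound 2 in turn. None of them shows a size or a direction, so no step beyond the usual scatter is expected in this assay for this change. The estimated outcome is a step that the limit leaves unreadable from compound 3 to compound 4 for this swap. Compound 4 is estimated at 0.7 h with an expected range of 0.35 h to 2 h and will most likely again be reported as a limit.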

Compound 4, half-life: > 0.5 h
Compound 4 was reported as a limit (the forecaster's own chance of this, stated with the estimate: 80%); the middle value is on the limit's open side.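

Compound 4 also comes back as a limit and not as a number, so its steps from compound 1, compound 2 and compound 3 cannot be read in size or direction. All four compounds now stand at one limit: the limit of > 0.5 h in this assay, at which 4 of the 4 values shown sit. The compounds shown leave open how long each actually lasts in this assay and whether any of these swaps on the shared core changes that.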